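This account rests on a few compounds, and the source may have more. Where it says the series, first, only, none or still open, it means among the compounds named here.

Measured compounds in a functional assay on MT4 cells (Homo sapiens) for antiproliferative activity, read by MTT assay, with a stated time of 96 h; on this read-out higher numbers stand for weaker inhibition and lower numbers for stronger inhibition:
- compound 1 `COc1ccc(N2C(=O)NC3(CSC4=C3C(=O)c3ncccc3C4=O)C2=O)cc1`: compound 1 gives 70 nM
- compound 2 `O=C1NNC(=O)C2(CSC3=C2C(=O)c2ncccc2C3=O)N1`: compound 2 gives 550 nM; 500 nM; 550 nM (3 entries)
- compound 3 `O=C1NC(=O)C2(CSC3=C2C(=O)c2ncccc2C3=O)N1`: compound 3 gives 130 nM; 120 nM; 130 nM (3 entries)

Compound 1 shows the lowest of the three numbers in this assay. Its value and that of compound 3 lie within the usual scatter of each other, so no order between them is claimed; compound 2 gives a clearly higher number, as its repeated entries show (the several entries of compound 2 in this assay, 550 nM; 500 nM; 550 nM (3 entries)), while the entries of compound 3 sit close together (the several entries of compound 3 in this assay, 130 nM; 120 nM; 130 nM (3 entries)). Two further entries exist for compound 1 without a single number.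

Compound 4 `CCN(CC)c1ccc(N2C(=O)NC3(CSC4=C3C(=O)c3ncccc3C4=O)C2=O)cc1` is not yet measured. It differs from compound 1 by diethylamino in place of methoxy on an aromatic carbon. Within the data shown here, no measured pair changes this position, so nothing in the data sets the size or direction of such a step. The expectation is a step of no size beyond the scatter, with a 1.1-fold higher number from compound 1 to compound 4 (0.03 log units; within the scatter) as the working guess. Compound 4 is therefore estimated at 75 nM, with a range from 25 nM to 220 nM.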

Compound 4, half-maximal inhibitory concentration: 8 nM
Beside the measured number, compound 4's estimate is 9.4-fold (0.97 log units) above it; the measured number lies below the stated range.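

The aromatic carbon carrying methoxy in compound 1 is a position that responds to substitution: in this assay, diethylamino in place of methoxy gives an 8.8-fold lower number from compound 1 to compound 4 (0.94 log units; beyond the scatter). Among these compounds, this is the first single-place step, since the earlier compounds offered no pair differing in one place, and with it compound 4 reaches 8 nM. Nothing measured in the series bears on why this step occurs.

A single step cannot separate the contribution of the nitrogen from that of the two ethyl chains, so a plain amine, dimethylamino or a purely carbon chain such as butyl would be needed at this carbon to tell them apart. As far as these compounds go, whether a carboxylic acid here would move the number in either direction also remains open.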